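Working notes: pyridin-2-yl for benzyl on the aromatic nitrogen

The source may report more compounds than this note shows. Statements on the series, on what has been measured and on what is new or still open speak of the compounds shown alone.

Measured compounds: compound 1 `Nc1cc(Cc2ccn(-c3ccc(F)cc3)n2)c2nn[nH]c2n1` gives 700 nM in an assay on cells for inhibition of thyroid peroxidase (Homo sapiens), with stated times of 10 min and 15 min; a lower number here means a stronger inhibitor, a higher number a weaker inhibitor; compound 2 `Nc1cc(Cc2ccn(Cc3cccc(Cc4ccccc4)c3)n2)c2nn[nH]c2n1` gives 1900 nM; compound 3 `Nc1cc(Cc2ccn(Cc3ccccc3)n2)c2nn[nH]c2n1` gives 2300 nM.

Compound 3 holds the highest number of the three. Compound 2 lies within the scatter of it (a 1.2-fold higher number from compound 2 to compound 3 (0.08 log units; within the scatter)), while compound 1 is clearly stronger (a 3.3-fold higher number from compound 1 to compound 3 (0.52 log units; beyond the scatter)). Compound 4 `Nc1cc(Cc2ccn(-c3ccccn3)n2)c2nn[nH]c2n1` differs from compound 3 by pyridin-2-yl in place of benzyl on an aromatic nitrogen. Within the data shown here, the only step that bears on this is a 3.3-fold higher number from compound 1 to compound 3 (0.52 log units; beyond the scatter), where an aryl group rather than benzyl on that nitrogen gave the lower number. Since the present change again removes benzyl in favour of an aryl, a lower number in this assay is expected for compound 4, of roughly that size. The estimate for compound 4 is 800 nM (range 350 nM to 1800 nM), an expected step of a 2.9-fold lower number from compound 3 to compound 4 (0.46 log units; beyond the scatter).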

Compound 4, half-maximal inhibitory concentration: 2000 nM
For compound 4 the middle estimate is 2.5-fold (0.40 log units) below the measured one; the whole stated range lies below it.
By their numbers in this assay, from the lowest: compound 1; then compounds 2, 4 and 3 (each within the scatter of the next).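

Pyridin-2-yl in place of benzyl on the aromatic nitrogen shows a 1.2-fold lower number from compound 3 to compound 4 (0.06 log units; within the scatter) in this assay and so no real change, whereas pyridin-2-yl in place of 4-fluorophenyl shows a 2.9-fold higher number from compound 1 to compound 4 (0.46 log units; beyond the scatter) and gives up the advantage of compound 1. An aromatic ring set directly on that nitrogen is therefore not enough for the lower number; among these compounds it goes with 4-fluorophenyl alone. Nothing at hand accounts for this difference. Open, on these data alone, is whether plain phenyl, 4-chlorophenyl or 4-methoxyphenyl on that nitrogen would keep the number of compound 1, which would separate the part played by the fluorine from that of the ring itself.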